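Adding a Methoxy Group to the Phenyl Ring

The source may report more compounds than this note shows. Statements on the series, on what has been measured and on what is new or still open speak of the compounds shown alone.

Compound 1 `COc1cc(/C=C/C(=O)c2cccc(-n3cc(-c4ccccc4)[nH]c3=O)c2)ccc1O` was tested in a functional assay on UACC-62 cells (Homo sapiens) for inhibition (a higher number here means a weaker inhibitor of growth, a lower number a stronger inhibitor of growth), where compound 1 gives 2010 nM. Among the compounds with values here, compound 2 `O=C(/C=C/c1cccc(O)c1)c1cccc(-n2cc(-c3ccccc3)[nH]c2=O)c1` gives 3650 nM in the same assay, and the step of a 1.8-fold higher number from compound 1 to compound 2 (0.26 log units; within the scatter) is the only comparison available. That step swaps the group at the far end of the chain and leaves the phenyl ring on the core untouched. Compound 3 `COc1ccc(-c2cn(-c3cccc(C(=O)/C=C/c4ccc(O)c(OC)c4)c3)c(=O)[nH]2)cc1` differs from compound 1 by methoxy in place of hydrogen on an aromatic carbon, on an aromatic carbon of a six-membered aromatic ring of carbon only. Within the data shown here, no measured step touches that ring, so nothing beyond the scatter is expected. The step of a 1.0-fold lower number from compound 1 to compound 3 (0.00 log units; within the scatter) is what is expected. Compound 3 is estimated at 2000 nM, within a range from 900 nM to 4500 nM.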

Compound 3, concentration for 50% growth inhibition: 3960 nM
Compound 3: middle estimate off by 2.0-fold (0.30 log units), on the low side; the measured number falls inside the stated range.
By their numbers in this assay, from the lowest: compounds 1, 2 and 3 (each within the scatter of the next).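

In this assay, methoxy in place of hydrogen on the phenyl ring, para to a large group, gives a 2.0-fold higher number from compound 1 to compound 3 (0.29 log units; within the scatter). Within the data shown here, this is the first reading at this ring, and it shows that phenyl to 4-methoxyphenyl leaves growth inhibition within the usual scatter of the assay. No supporting measurement is available to explain this result. Still open, from the compounds shown here alone, is whether a different group at this place, such as an amine or a carboxylic acid, would move the number beyond the scatter.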